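Swapping the aryl group on the shared core of compound 2

The source may report more compounds than this note shows. Statements on the series, on what has been measured and on what is new or still open speak of the compounds shown alone.

Compound 2 `COc1ccc(C2=C(c3ccc(SC)cc3)CC3CCCN3C2=O)cc1C` gives 15000 nM in a functional assay on SK-OV-3 cells (Homo sapiens) for cytotoxicity; a higher number here means a weaker inhibitor of growth, a lower number a stronger inhibitor of growth. Among the two numbers at hand that is the higher one; compound 3 `CSc1ccc(C2=C(c3ccc(C)cc3)C(=O)N3CCCC3C2)cc1` gives 9000 nM in this assay, and a 1.7-fold lower number from compound 2 to compound 3 (0.22 log units; within the scatter) lies within the scatter, so the two cannot be ranked. Compound 1 `COc1ccc(C2=C(c3ccc(SC)cc3)CC3CCCN3C2=O)cc1O` reaches only a limit of the assay, > 100000 nM in this assay. The steps of an at least 6.6-fold lower number from compound 1 to compound 2 (0.82 log units; beyond the scatter) and an at least 11-fold lower number from compound 1 to compound 3 (1.04 log units; beyond the scatter) start from that limit of > 100000 nM in this assay, at which 1 of the 3 values shown sits, and are therefore at least as large as stated.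

Compound 4 `CSc1ccc(C2=C(c3ccc(F)cc3)C(=O)N3CCCC3C2)cc1` has not yet been measured. (4-fluorophenyl in place of 4-methoxy-3-methylphenyl on a double-bonded ring carbon). The measured step that bears most directly on this is a 1.7-fold lower number from compound 2 to compound 3 (0.22 log units; within the scatter), where 4-methylphenyl took the place of the same 4-methoxy-3-methylphenyl and the number stayed within the scatter. The steps from compound 1 concern a hydroxy-bearing group and speak less directly to it. The step of a 1.7-fold lower number from compound 2 to compound 4 (0.22 log units; within the scatter) is therefore expected to stay within the scatter. Compound 4 is estimated at 9000 nM in this assay, between 3000 nM and 30000 nM.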

Compound 4, concentration for 50% growth inhibition: 30000 nM
Compound 4: middle estimate off by 3.3-fold (0.52 log units), on the low side; the range from low to high includes it.
By their numbers in this assay, from the lowest: compounds 3, 2 and 4 (each within the scatter of the next, the first and the last beyond it). At a limit, above all of these: compound 1.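

In the step of a 2.0-fold higher number from compound 2 to compound 4 (0.30 log units; within the scatter), 4-fluorophenyl on the double-bonded ring carbon stays within the scatter of 4-methoxy-3-methylphenyl, just as 4-methylphenyl did. For the compounds shown here, the step of a 3.3-fold higher number from compound 3 to compound 4 (0.52 log units; beyond the scatter), fluoro in place of methyl on an aromatic carbon, is the only step beyond the scatter that does not start from compound 1, so a single substituent on this aryl group can shift the number even though neither compound 3 nor compound 4 can be ranked against compound 2. The step of an at least 3.3-fold lower number from compound 1 to compound 4 (0.52 log units; beyond the scatter) gives only a bound, resting on a limit: the limit of > 100000 nM in this assay, at which 1 of the 4 values shown sits.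

From the compounds shown here alone, whether an amine or a carboxylic acid in place of the fluoro would give a lower number than compound 3 with 9000 nM stays open. The 4-(methylsulfanyl)phenyl group is common to all the compounds shown, so the effect of a longer chain on its sulfur is open too.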